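Halogen exchange at the aryl ether of compound 1

This account rests on a few compounds, and the source may have more. Where it says the series, first, only, none or still open, it means among the compounds named here.

Three compounds of the series have a number in a toxicity assay on the whole organism with Rattus norvegicus as the target, at a dose of 200 mg/kg by the oral route; on this read-out higher numbers stand for a stronger effect at the one dose given and lower numbers for a weaker effect. Compound 1 `Brc1ccccc1OCC1=NCCO1` gives 90% and stands highest of the three numbers. Compound 2 `Cc1cccc(OCC2=NCCO2)c1` is the nearest to it: in this assay compound 2 gives 70%, a gap to compound 1 that lies beyond the scatter. Compound 3 `Fc1ccc(OCC2=NCCO2)cc1` is the furthest: in this assay compound 3 gives 40%, again a gap beyond the scatter. Within the data shown here, no two of the measured compounds differ in a single place, so no measured step isolates one change.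

Compound 4 `Fc1ccccc1OCC1=NCCO1` is still to be measured. Against compound 1 the change is fluoro in place of bromo on an aromatic carbon. Among the measured compounds only compound 3 carries a fluoro group, and compound 3 gives 40% in this assay, but it differs from compound 4 in more than that one place, so its number is a loose guide only. A downward step from compound 1 is expected, of a size beyond the scatter, and the estimated step from compound 1 to compound 4 is a number 30 percentage points lower from compound 1 to compound 4 (beyond the scatter). Compound 4 is accordingly expected to give about 60% in this assay, with a range from 35% to 85%.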

Compound 4, a percentage reported as activity, at one dose (the size of the read-out at that dose, not a potency): 60%
For compound 4 middle estimate and measured number coincide at the digits printed, and the stated range covers the measured number.
By their numbers in this assay, from the lowest: compound 3; then compounds 4 and 2 (each within the scatter of the next); then compound 1.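

In this assay, among these compounds, the exchange of bromo for fluoro on an aromatic carbon, ortho to a group of 7 heavy atoms, gives the first step that isolates one change: a number 30 percentage points lower from compound 1 to compound 4 (beyond the scatter). Among the compounds shown here, the earlier compounds each differ from compound 1 in more than one place, so only this pair shows that the identity of the halogen at this position alone moves the read-out at the one dose given. The effect is not lost with this exchange, since compound 4 still gives 60% in this assay.

No measurement at hand bears on the reason for this step.

The compounds shown leave open where chloro or an amine on this same aromatic carbon would fall relative to bromo and fluoro, and so whether the read-out follows any order across substituents at this position. They also leave open whether the same exchange gives a step of similar size at another place on the aromatic ring, or in a compound carrying a longer chain at the ether.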